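Ethyl for Fluoro on a Fused Aromatic Core

The compounds below may be only part of what the source reports. "The series", "measured", "known", "first", "only" and "open" are said of these compounds alone.

Measured compounds:
compound 1, `O=C(O)c1cnc2c(F)cccc2c1`, 150 mg/kg
compound 2, `FC(F)(F)c1ccc2cc(-c3nn[nH]n3)cnc2c1`, 25 mg/kg

In a functional assay on the whole organism (strain Sprague-Dawley) for inhibition, with Rattus norvegicus as the target (a higher number here means that more compound is needed for the effect, a lower number that less compound is needed), compound 1 gives 150 mg/kg, the highest of the two numbers recorded, while compound 2 gives 25 mg/kg, a gap beyond the usual scatter. Compound 3, `CCc1cccc2cc(C(=O)O)cnc12`, has not yet been measured. It differs from compound 1 in one place: ethyl in place of fluoro on an aromatic carbon. Going by the values given here, no pair of measured compounds shows what such a swap does, so the direction is open. A step of a 1.3-fold lower number from compound 1 to compound 3 (0.10 log units; within the scatter) from compound 1 to compound 3 is expected, staying within the scatter. Compound 3 is estimated at 120 mg/kg, between 40 mg/kg and 400 mg/kg.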

Compound 3, minimum effective dose: 75 mg/kg
Compound 3: the middle estimate sits 1.6-fold (0.20 log units) above what was measured, and the stated range covers the measured number.
By their numbers in this assay, from the lowest: compound 2; then compounds 3 and 1 (each within the scatter of the next).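

In this assay, ethyl in place of fluoro on this aromatic carbon gives a 2.0-fold lower number from compound 1 to compound 3 (0.30 log units; within the scatter). The position therefore accepts ethyl, with 2 heavy atoms, in place of fluoro, with 1, without a difference that can be told from the scatter. No supporting measurement bears on why this is so.

Going by these compounds, whether a longer chain, an amine or a methoxy group would fit here equally well remains open. So does whether the same swap would give a similar result on a core carrying something other than the carboxylic acid.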